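The source may hold more compounds than are shown below. What is called first, only, known or untested is meant among the compounds shown, and "the series" means these compounds.

Working notes on the series. In a functional assay on the whole organism for inhibition, with Rattus norvegicus as the target (a higher number here means a weaker inhibitor, a lower number a stronger inhibitor), compound 1 `O=C1ON=C(c2cccs2)/C1=C/c1ccc(O)cc1` gives 4200 nM, compound 2 `O=C1ON=C(c2cccs2)/C1=C/c1ccc(F)cc1` gives 4800 nM, and compound 3 `CC(=O)Oc1ccc(/C=C2\C(=O)ON=C2c2cccs2)cc1` gives 4500 nM. Compound 3 lies within the scatter of both other compounds, so these numbers give no order among the three.

The next compound is compound 4 `COc1ccc(/C=C2\C(=O)ON=C2c2cccs2)cc1`. It differs from compound 3 by methyl in place of acetyl on an oxygen on an aromatic ring, or acetoxy to methoxy: methyl in place of acetyl on an oxygen on an aromatic ring.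

Among the measured compounds shown here, three measured steps bear on this change. The closest is a 1.1-fold higher number from compound 1 to compound 3 (0.03 log units; within the scatter), with acetyl in place of hydrogen on an oxygen on an aromatic ring. Also relevant are a 1.1-fold lower number from compound 2 to compound 3 (0.03 log units; within the scatter), with acetoxy in place of fluoro, and a 1.1-fold higher number from compound 1 to compound 2 (0.06 log units; within the scatter), with fluoro in place of hydroxy. All three lie within the scatter. For the measured compounds named here, no compound carrying methoxy has been measured, so this reading rests on three compounds only.

In this assay, no step beyond the scatter and no particular direction is therefore expected. The expected step is no change at the digits printed from compound 3 to compound 4 (within the scatter). The estimate for compound 4 is 4500 nM, with an expected range of 2500 nM to 8000 nM.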

Compound 4, half-maximal inhibitory concentration: 2500 nM
Estimate against measurement, compound 4: 1.8-fold (0.26 log units) above, within the range that was stated.
By their numbers in this assay, from the lowest: compounds 4, 1, 3 and 2 (each within the scatter of the next).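

In this assay, the change from acetoxy to methoxy, methyl in place of acetyl on an oxygen on an aromatic ring, gives a 1.8-fold lower number from compound 3 to compound 4 (0.26 log units; within the scatter) and so stays within the scatter. The two other new comparisons agree: methyl in place of hydrogen on that oxygen gives a 1.7-fold lower number from compound 1 to compound 4 (0.23 log units; within the scatter) and going from fluoro to methoxy gives a 1.9-fold lower number from compound 2 to compound 4 (0.28 log units; within the scatter) and both are also within the scatter. The earlier compounds covered only hydrogen and acetyl on this oxygen, and methyl now adds a third group there, without a carbonyl, that leaves the number within the scatter of the others, while no measurement shown here bears on the reason for these small steps.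

Going by these compounds, it remains open whether a longer chain on this oxygen, such as butyl or benzyl, or an amine or a carboxylic acid on the aromatic carbon, would give a step beyond the scatter. All four compounds also share the rest of the core, so these numbers say nothing about how changes elsewhere in the structure would read.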